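Bromophenyl to dichlorophenyl on a second core

The source may hold more compounds than are shown below. What is called first, only, known or untested is meant among the compounds shown, and "the series" means these compounds.

The three measured compounds:
compound 1, `COc1cc(/C=C2\CN(C)C/C(=C\c3ccc(Br)cc3)C2=O)cc(OC)c1`, in a functional assay on HeLa cells (Homo sapiens) for cytotoxicity, read by MTT assay, with a stated time of 24 h (a lower number here means a stronger inhibitor, a higher number a weaker inhibitor), compound 1 gives 5900 nM.
compound 2, `COc1cc(/C=C2\CN(C)C/C(=C\c3ccc(Cl)cc3Cl)C2=O)cc(OC)c1`, in this assay compound 2 gives 7760 nM.
compound 3, `CN1C/C(=C\c2ccc(Br)cc2)C(=O)/C(=C/c2cccc([N+](=O)[O-])c2)C1`, in this assay compound 3 gives 11900 nM.

Compound 1 and compound 2 share a core and differ in one place: 2,4-dichlorophenyl in place of 4-bromophenyl on a double-bonded chain carbon bound to a double-bonded ring carbon. That change made a 1.3-fold higher number from compound 1 to compound 2 (0.12 log units; within the scatter). Compound 3 carries a different core; how the core of compound 3 differs from the core of compound 1 is not broken down here. Its value in this assay sits within the scatter of both compound 1 and compound 2, so none of the three can be set apart from the others.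

Compound 4, `CN1C/C(=C\c2cccc([N+](=O)[O-])c2)C(=O)/C(=C/c2ccc(Cl)cc2Cl)C1`, has not yet been measured. It differs from compound 3 in exactly the same way that compound 2 differs from compound 1: 2,4-dichlorophenyl in place of 4-bromophenyl on a double-bonded chain carbon bound to a double-bonded ring carbon. Because the step of a 1.3-fold higher number from compound 1 to compound 2 (0.12 log units; within the scatter) stayed within the scatter, the same change on the core of compound 3 is expected to leave the number close to where compound 3 stands, and a step of about a 1.3-fold higher number from compound 3 to compound 4 (0.10 log units; within the scatter) is estimated. Among the compounds with values here, there is only one earlier instance of this change, so the expectation rests on a single pair. For compound 4 in this assay the estimate is 15000 nM, with a likely range from 7000 nM to 32000 nM.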

Compound 4, half-maximal inhibitory concentration: 8900 nM
Estimate against measurement, compound 4: 1.7-fold (0.23 log units) above, and the stated range covers the measured number.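

In this assay, putting 2,4-dichlorophenyl in place of 4-bromophenyl on a double-bonded chain carbon bound to a double-bonded ring carbon gave a 1.3-fold lower number from compound 3 to compound 4 (0.13 log units; within the scatter) on the second core. This step and the earlier instance of the change cannot be told apart: the same change on two cores in this assay, a 1.3-fold higher number (0.12 log units; within the scatter) from compound 1 to compound 2 and a 1.3-fold lower number (0.13 log units; within the scatter) from compound 3 to compound 4, 1.8-fold (0.25 log units) apart, within the scatter of two such steps. On these two cores, then, the change left the number within the scatter both times, so in this assay it carried from one core to the other without a detectable effect, but this does not show that the two cores respond identically, that any small true step exists in either direction, or that the same would hold on a third core.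

The compounds shown leave open whether a group of another kind in the same place, such as an amine, a carboxylic acid or a phenyl ring bearing a longer chain, would move the number beyond the scatter on either core. They also leave open whether the change would stay as quiet in other cell lines or over other exposure times, since all four values come from a single cytotoxicity read-out on one cell line.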